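Chloro next to the ring nitrogen and cytotoxicity

This account rests on a few compounds, and the source may have more. Where it says the series, first, only, none or still open, it means among the compounds named here.

Measured compounds:
compound 1 `COc1ccccc1S(=O)(=O)/C=C/c1ncccc1Cl`: 100%
compound 2 `COc1cccc(S(=O)(=O)/C=C/c2cccc(Cl)n2)c1`: 89.3%
compound 3 `COc1ccc(S(=O)(=O)/C=C/c2ccccn2)cc1`: 100%

Three compounds were tested in an ADME assay on BV-2 cells (Mus musculus) for cytotoxicity, with a stated time of 24 h, tested at 50 uM; a higher number here means a weaker effect of the compound at the concentration tested, a lower number a stronger effect. Compound 1 gives 100%, compound 2 gives 89.3% and compound 3 gives 100% in this assay. Compound 3 stands level with compound 1 at the digits shown, and together these two are the highest of the three numbers; compound 2 is lower than compound 3 by a margin that lies beyond the usual scatter.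

The next compound, compound 4 `COc1ccc(S(=O)(=O)/C=C/c2cccc(Cl)n2)cc1`, has not been measured yet. It differs from compound 3 in one place: chloro in place of hydrogen on an aromatic carbon. For the measured compounds named here, the same chloro group sits next to the ring nitrogen in compound 2, the one compound of the three that came in lower, though compound 2 also differs from compound 3 elsewhere and no single step links them.

With no direct comparison of this exact change available, compound 4 is expected to move only slightly downward, a step of a number 6 percentage points lower from compound 3 to compound 4 (within the scatter) in this assay. Compound 4 is therefore estimated at 94%, with a likely range from 80% to 100%.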

Compound 4, a percentage reported as activity, at one concentration (the size of the read-out at that concentration, not a potency): 85%
Compound 4: middle estimate off by 9 percentage points, on the high side; the range from low to high includes it.
By their numbers in this assay, from the lowest: compounds 4 and 2 (each within the scatter of the next); then compounds 1 and 3 (each within the scatter of the next).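

Chloro in place of hydrogen on an aromatic carbon, next to the ring nitrogen and meta to a large group, now has a direct reading in this assay, with a step of a number 15 percentage points lower from compound 3 to compound 4 (beyond the scatter) and nothing else in the structure changed. The lower number of compound 2 could not be tied to any one feature, whereas this pair shows that the chloro alone is enough to lower the number at this place, leaving compound 4 at 85% and compound 2 at 89.3%, within the scatter of each other. The data offered here give no measured explanation for the step.

Going by these compounds, whether another group at this place, such as fluoro, methyl or an amine, would lower the number as well remains open, so the step cannot yet be assigned to chloro in particular rather than to any replacement of the hydrogen. Also open, on these data alone, is how far the step depends on the placement of the chloro and the methoxy group, since compound 1, which carries its chloro elsewhere on the ring, gives 100% but differs from compound 4 in more than one place.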